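Ileum functional series: tetrazole in place of the chain acid

The source may hold more compounds than are shown below. What is called first, only, known or untested is meant among the compounds shown, and "the series" means these compounds.

Measured compounds:
compound 1 `CCCc1c(OCCCCCC(=O)O)ccc(C(=O)CC)c1O` — 6.1
compound 2 `CCCc1c(OCCCCCC(=O)O)ccc(C(C)=O)c1O` — 6

In a functional assay on ileum (Cavia porcellus) for inhibition of cysteinyl leukotriene receptor (Homo sapiens) (on this read-out lower numbers stand for lower potency and higher numbers for higher potency (the scale is a negative logarithm)), compound 1 gives 6.1, and compound 2 gives 6. Within the data shown here, the only measured step, a number 0.10 log units lower from compound 1 to compound 2 (within the scatter), lies within the scatter, so compound 2 and compound 1 are not distinguishable on this read-out; compound 2 has the lower of the two numbers, but that order carries no weight.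

Compound 3 `CCCc1c(OCCCCCc2nn[nH]n2)ccc(C(C)=O)c1O` keeps the core of compound 2 and changes only the end of the chain: 2H-tetrazol-5-yl in place of carboxy on a saturated chain carbon, five bonds along the chain from an oxygen on an aromatic ring. Among the measured compounds shown here, no measured step bears on this change; the single step between compound 1 and compound 2 concerns the group on the carbonyl carbon at the other end of the core and says nothing about the chain end. The expectation for compound 3 therefore rests on compound 2 alone, and the step of a number 0.20 log units higher from compound 2 to compound 3 (within the scatter) is expected to be small, without a direction that the data could support. Compound 3 is estimated at 6.2, with a range from 5.5 to 7 that reflects the absence of any comparable measured step.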

Compound 3, negative logarithm of the antagonist equilibrium constant: 6.6
For compound 3 the middle estimate is 0.40 log units below the measured one; the measured number falls inside the stated range.
By their numbers in this assay, from the lowest: compounds 2 and 1 (each within the scatter of the next); then compound 3.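

In this assay, the chain end is the only place shown where a change moves the number beyond the scatter: 2H-tetrazol-5-yl in place of carboxy gives a number 0.60 log units higher from compound 2 to compound 3 (beyond the scatter), whereas the change at the carbonyl carbon gives a number 0.10 log units lower from compound 1 to compound 2 (within the scatter). The position therefore accepts a five-membered aromatic ring with 4 hetero atoms in place of carboxy without loss, and compound 3 reaches 6.6, so a carboxy group at this chain end is not required for activity on this read-out, although this rests on a single matched pair. Nothing available here accounts for the size or direction of this step.

As far as these compounds go, it remains open whether the same replacement gives a similar step on the core of compound 1, where the carbonyl carbon carries the longer chain, since the 2H-tetrazol-5-yl group appears here on the core of compound 2 only. Also open, from the compounds shown here alone, is how the number responds to a shorter or longer chain between the aromatic oxygen and the 2H-tetrazol-5-yl group, or to other chain ends such as a sulfonamide or a primary amide.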